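Carboxy to morpholinyl carbonyl: growth inhibition notes

This account rests on a few compounds, and the source may have more. Where it says the series, first, only, none or still open, it means among the compounds named here.

Compound 1 `O=C(O)/C=C/c1ccncc1-c1ccc2cc[nH]c2c1` sits at the limit of a functional assay on A549 cells (Homo sapiens) for inhibition, read by sulforhodamine B assay, with a stated time of 72 h; on this read-out lower numbers stand for stronger inhibition of growth and higher numbers for weaker inhibition of growth; in this assay compound 1 gives > 10000 nM, a limit rather than a number. Compound 2 `CNC(=O)/C=C/c1ccncc1-c1ccc2[nH]ccc2c1` likewise returns a limit in this assay, > 10000 nM. Among the compounds with values here, compound 3 `O=C(/C=C/c1ccncc1-c1ccc2ccccc2c1)NC1CC1` is the only member with a measured number, giving 5840 nM in this assay. Compound 1 therefore stands at the top of what is seen, where (the limit of > 10000 nM in this assay, at which 2 of the 3 values shown sit). Compound 4 `O=C(/C=C/c1ccncc1-c1ccc2cc[nH]c2c1)N1CCOCC1` carries the change (morpholin-4-yl in place of hydroxy on a carbonyl carbon), the carboxy of compound 1 becoming a (morpholin-4-yl)carbonyl. Within the data shown here, no measured pair isolates this change; compound 3, the single amide with a number, also lies in the weak range. The expected step is small, an at least 1.4-fold lower number from compound 1 to compound 4 (0.15 log units; that floor lies within the scatter), likely within the scatter. Compound 4 is expected at 7000 nM, in the range 2000 nM to 25000 nM.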

Compound 4, concentration for 50% growth inhibition: > 10000 nM
Compound 4: a limit, no number; the forecaster's own chance of this, stated with the estimate: 40%; middle value at least 1.4-fold (0.15 log units) from the limit.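

Compound 1 and compound 4 both return limits in this assay, so no step can be read for the change from carboxy to (morpholin-4-yl)carbonyl. The compounds shown leave open how far any limit compound lies past the shared limit: the limit of > 10000 nM in this assay, at which 3 of the 4 values shown sit.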